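Nitro to trifluoromethyl on the urea aryl ring

The source may report more compounds than this note shows. Statements on the series, on what has been measured and on what is new or still open speak of the compounds shown alone.

Measured compounds:
compound 1 `CCC1(CC)CC(C)(C)c2cc(NC(=S)Nc3ccc([N+](=O)[O-])cc3)ccc2O1`, 2900 nM
compound 2 `CCC1(CC)CC(C)(C)c2cc(NC(=O)Nc3ccc([N+](=O)[O-])cc3)ccc2O1`, 2170 nM
compound 3 `CCC1(CC)CC(C)(C)Oc2ccc(NC(=O)Nc3ccc([N+](=O)[O-])cc3)cc21`, 2050 nM

All three numbers come from a functional assay on A2780 cells (Homo sapiens) for inhibition, with a stated time of 72 h; on this read-out higher numbers stand for weaker inhibition and lower numbers for stronger inhibition. Compound 3 carries the lowest of the three, but its gap to compound 2 and its gap to compound 1 both lie within the scatter of this assay, so no ranking among the three is claimed; the set reads as a flat cluster.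

Compound 4 `CCC1(CC)CC(C)(C)Oc2ccc(NC(=O)Nc3ccc(C(F)(F)F)cc3)cc21` has not been measured. It differs from compound 3 in one place: trifluoromethyl in place of nitro on an aromatic carbon. Among the measured compounds shown here, no measured pair shows the same change, so there is no step in this assay to rest on; the only guide is the narrow spread of the three measured numbers.

For compound 4 the step is expected to stay within the scatter, a 1.3-fold higher number from compound 3 to compound 4 (0.10 log units; within the scatter), with no clear direction. The estimate for compound 4 is therefore 2600 nM, within a range of 1000 nM to 7000 nM.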

Compound 4, half-maximal inhibitory concentration: 2430 nM
Estimate against measurement, compound 4: 1.1-fold (0.03 log units) above; measured number inside the range.
By their numbers in this assay, from the lowest: compounds 3, 2, 4 and 1 (each within the scatter of the next).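

Trifluoromethyl in place of nitro on an aromatic carbon, para to a large group, gives in this assay a 1.2-fold higher number from compound 3 to compound 4 (0.07 log units; within the scatter) and provides the first single-place change read at this position. Among the compounds shown here, the nitro group is therefore not needed to hold the inhibition of this series at its present level, and compound 4 joins the flat cluster formed by the earlier compounds. No measurement shown here explains why the two groups read alike.

Still open, as far as these compounds go, is whether an amine, a carboxylic acid or a nitrile on the same aromatic carbon would also stay within the scatter of compound 3, or would move the number clearly in either direction. Also open, from the compounds shown here alone, is whether the same exchange of nitro for trifluoromethyl would read alike on the core of compound 2.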